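The source may report more compounds than this note shows. Statements on the series, on what has been measured and on what is new or still open speak of the compounds shown alone.

In an ADME assay on microsomes from liver (Homo sapiens) for pharmacokinetics, read by LC-MS, with a stated time of 60 min, tested at 1 uM (a lower number here means slower removal, a higher number faster removal of the compound), compound 1, `O=C(NCc1ccc(S(=O)(=O)c2cccc(C(F)(F)F)c2)cc1)N1Cc2ccncc2C1`, gives 14 mL/min/kg. Compound 2, `O=C(NCc1ccc(S(=O)(=O)c2cncc(C(F)(F)F)c2)cc1)N1Cc2ccncc2C1`, gives 13 mL/min/kg, and compound 3, `O=C(NCc1ccc(S(=O)(=O)c2cc(F)cc(F)c2)cc1)N1Cc2ccncc2C1`, gives 8 mL/min/kg. Compound 1 therefore stands within the scatter of both neighbours and cannot be separated from either.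

The next compound to be tested is compound 4, `O=C(NCc1ccc(S(=O)(=O)C2CCCCC2)cc1)N1Cc2ccncc2C1`, which has cyclohexyl in place of 3-(trifluoromethyl)phenyl on a sulfonyl sulfur.

Three measured steps change the same place. Moving to 5-(trifluoromethyl)pyridin-3-yl gives a 1.1-fold lower number from compound 1 to compound 2 (0.03 log units; within the scatter). Moving to 3,5-difluorophenyl gives a 1.8-fold lower number from compound 1 to compound 3 (0.24 log units; within the scatter), and the exchange between those two groups gives a 1.6-fold lower number from compound 2 to compound 3 (0.21 log units; within the scatter). All three are small, but each one puts one six-membered aromatic ring in place of another. None of them tests a non-aromatic ring, so they bear on this change only in part, and the data offer no measured guide to its direction.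

What is expected in this assay is therefore no step beyond the scatter, namely a 1.2-fold higher number from compound 1 to compound 4 (0.08 log units; within the scatter), held with less confidence than the measured steps alone would suggest. For compound 4 the estimated clearance is 17 mL/min/kg, with an expected range from 8 mL/min/kg to 36 mL/min/kg.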

Compound 4, clearance: 16 mL/min/kg
Beside the measured number, compound 4's estimate is 1.1-fold (0.03 log units) above it; measured number inside the range.
By their numbers in this assay, from the lowest: compounds 3, 2, 1 and 4 (each within the scatter of the next).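

In this assay, cyclohexyl, the only non-aromatic ring among the compounds shown on a sulfonyl sulfur, cannot be separated from any of the three aromatic groups: the steps are a 1.1-fold higher number from compound 1 to compound 4 (0.06 log units; within the scatter), a 1.2-fold higher number from compound 2 to compound 4 (0.09 log units; within the scatter) and a 2.0-fold higher number from compound 3 to compound 4 (0.30 log units; within the scatter). So this position now tolerates more than an exchange of one six-membered aromatic ring for another, since a non-aromatic ring of carbon only, with fewer heavy atoms and no fluorine, also leaves the clearance within the scatter of every earlier compound. No measurement shown here accounts for this outcome, and none assigns a cause to it.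

The compounds shown leave open whether a ring carrying oxygen or nitrogen, such as tetrahydropyran-4-yl or piperidin-4-yl, or an open chain such as tert-butyl or n-butyl, on a sulfonyl sulfur would take the clearance beyond the scatter. They also leave open whether a smaller ring, such as cyclopropyl, or a cyclohexyl bearing a hydroxyl or a carboxylic acid would give a step that can be read in this assay.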